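Stripping the aryl from the amidine nitrogen of compound 2

The compounds below may be only part of what the source reports. "The series", "measured", "known", "first", "only" and "open" are said of these compounds alone.

Measured compounds in a functional assay on DU-145 cells (Homo sapiens) for cytotoxicity, read by MTT assay, with a stated time of 48 h; on this read-out lower numbers stand for stronger inhibition and higher numbers for weaker inhibition:
- compound 1 `Cc1ccc(S(=O)(=O)/N=C(/CCNC2=CC(=O)c3ccccc3C2=O)Nc2ccccc2[N+](=O)[O-])cc1` gives 7590 nM
- compound 2 `Cc1ccc(S(=O)(=O)/N=C(/CCNC2=CC(=O)c3ccccc3C2=O)Nc2ccccc2I)cc1` gives 11700 nM
- compound 3 `COc1ccc(N/C(CCNC2=CC(=O)c3ccccc3C2=O)=N\S(=O)(=O)c2ccc(C)cc2)c(OC)c1` gives 67300 nM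

Compound 2 stands second highest of the three numbers in this assay. Its nearest neighbour is compound 1, with a 1.5-fold higher number from compound 1 to compound 2 (0.19 log units; within the scatter), a gap that lies within the scatter; its furthest is compound 3, with a 5.8-fold higher number from compound 2 to compound 3 (0.76 log units; beyond the scatter), a modest step beyond the scatter. The step of an 8.9-fold higher number from compound 1 to compound 3 (0.95 log units; beyond the scatter) points the same way.

Compound 4 `Cc1ccc(S(=O)(=O)/N=C(\N)CCNC2=CC(=O)c3ccccc3C2=O)cc1` differs from compound 2 by hydrogen in place of 2-iodophenyl on an amine nitrogen. Among the compounds with values here, none of the measured steps covers this change: all three swap one aryl group on that nitrogen for another, and the step from compound 2 to compound 3 shows that a change of the aryl alone can already shift the number beyond the scatter. Removing the aryl altogether is a larger change than any measured, so compound 4 is expected to give a step beyond the scatter toward higher numbers, a 2.6-fold higher number from compound 2 to compound 4 (0.41 log units; beyond the scatter), with wide uncertainty. Compound 4 is estimated at 30000 nM, within a range of 8000 nM to 120000 nM.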

Compound 4, half-maximal inhibitory concentration: 30900 nM
The estimate for compound 4 lay 1.0-fold (0.01 log units) below the measured number; measured number inside the range.
By their numbers in this assay, from the lowest: compounds 1 and 2 (each within the scatter of the next); then compound 4; then compound 3.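

In this assay, taking the aryl off the amine nitrogen does not put compound 4 at the weak end of the series. Hydrogen gives a higher number than either the 2-iodophenyl group (a 2.6-fold higher number from compound 2 to compound 4 (0.42 log units; beyond the scatter)) or the 2-nitrophenyl group (a 4.1-fold higher number from compound 1 to compound 4 (0.61 log units; beyond the scatter)), but a lower number than the 2,4-dimethoxyphenyl group (a 2.2-fold lower number from compound 3 to compound 4 (0.34 log units; beyond the scatter)), so at this position an aryl group is not favourable as such and the direction of the step depends on which aryl is present. Nothing available accounts for this order.

The compounds shown leave open where a plain phenyl or a small alkyl such as methyl on this nitrogen would fall relative to hydrogen. They also leave open whether a single methoxy group on the phenyl would be enough to give a number above that of compound 4.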